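Isobutyl ketone to ethyl carboxamide on the shared core

A few compounds are considered here, and "the series" means these few. Any claim that something is new, unique, unknown or untested is made for them only; others in the source may bear on it.

Three compounds of the series have a number in an assay on membranes from CHO cells for displacement of a labelled ligand from adenosine receptor A1 (Homo sapiens), read by scintillation counting, with a stated time of 60 min, tested at 1 uM; on this read-out higher numbers stand for more inhibition at the one concentration tested (going by the name of the read-out) and lower numbers for less inhibition. Compound 1 `CC1=C(C(=O)CC(C)C)C(c2ccoc2)NC(=O)N1` gives 23%, compound 2 `CC1=C(C(=O)C2CC2)C(c2ccsc2)NC(=O)N1` gives 2%, and compound 3 `CC1=C(C(=O)CC(C)C)C(c2ccsc2)NC(=O)N1` gives 37%, the highest of the three. Within the data shown here, the step of a number 14 percentage points higher from compound 1 to compound 3 (beyond the scatter) is modest; the step of a number 35 percentage points higher from compound 2 to compound 3 (beyond the scatter) is large, and it is the only measured step at the carbonyl carbon.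

Compound 4 `CCNC(=O)C1=C(C)NC(=O)NC1c1ccsc1` differs from compound 3 by ethylamino in place of isobutyl on a carbonyl carbon: cut one bond further out, isobutylcarbonyl becomes ethylcarbamoyl, on the carbonyl carbon whose other neighbour is a double-bonded ring carbon. Among the measured compounds shown here, the step from compound 2 to compound 3 shows that changing the group on this carbonyl carbon can move the read-out by a large amount, but no measured compound carries ethylamino there, so the direction is not fixed by the data. The step expected here is a number 22 percentage points lower from compound 3 to compound 4 (beyond the scatter), a fall beyond the scatter, taking the series back toward compound 2. Compound 4 is expected to give 15%, with a range from 0% to 35%.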

Compound 4, a percentage reported as inhibition, at one concentration (the size of the read-out at that concentration, not a potency): 3%
The estimate for compound 4 lay 12 percentage points above the measured number; the measured number falls inside the stated range.
By their numbers in this assay, from the lowest: compounds 2 and 4 (each within the scatter of the next); then compound 1; then compound 3.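

In this assay the carbonyl carbon now shows a second large step, a number 34 percentage points lower from compound 3 to compound 4 (beyond the scatter), so the isobutyl ketone stands apart from a second group as well as from cyclopropyl. Ethylamino and cyclopropyl, both on the thiophen-3-yl compounds, are not separated, with a number 1 percentage points higher from compound 2 to compound 4 (within the scatter), so these two different groups leave the read-out at the same level. No measurement at hand accounts for what sets isobutyl apart from these two groups.

Still open, as far as these compounds go, is whether the fall follows the entering nitrogen or the shorter chain: isobutylamino or an ethyl ketone on the same carbonyl carbon would separate the two. Also open, from the compounds shown here alone, is whether ethylamino gives a similar step when furan-3-yl stands in place of thiophen-3-yl.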